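The compounds below may be only part of what the source reports. "The series", "measured", "known", "first", "only" and "open" are said of these compounds alone.

Measured in a functional assay on A549 cells (Homo sapiens), read by sulforhodamine B assay, with a stated time of 5 days; a higher number here means a weaker inhibitor of growth, a lower number a stronger inhibitor of growth:
- compound 1 `OC[C@H]1O[C@@H](n2cc(F)c3c(-c4ccc[nH]4)ncnc32)[C@H](O)[C@@H]1O`: 190 nM
- compound 2 `OC[C@H]1O[C@@H](n2cc(F)c3c(-c4ccoc4)ncnc32)[C@H](O)[C@@H]1O`: 60 nM

Compound 2, at 60 nM, holds the lower of the two numbers, so it is the stronger inhibitor of growth of this pair. The next compound, compound 3 `OC[C@H]1O[C@@H](n2cc(F)c3c(-c4ccsc4)ncnc32)[C@H](O)[C@@H]1O`, keeps the shared core and has thiophen-3-yl in place of furan-3-yl on an aromatic carbon. Within the data shown here, only one measured step bears on this change: a 3.2-fold lower number from compound 1 to compound 2 (0.50 log units; beyond the scatter). That step also exchanges one five-membered aromatic ring for another at the same place, and it shows that such an exchange can move the number modestly. Among the measured compounds shown here, it is a different exchange, however, and no measurement yet compares furan-3-yl with thiophen-3-yl directly. The swap keeps the name and ring size of the group apart from its hetero atom, so no step beyond the scatter is expected in this assay, and no firm direction can be given. The estimated step is a 1.2-fold lower number from compound 2 to compound 3 (0.08 log units; within the scatter). For compound 3 the expected value is 50 nM, with an estimated range from 20 nM to 130 nM.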

Compound 3, concentration for 50% growth inhibition: 380 nM
Compound 3: middle estimate off by 7.6-fold (0.88 log units), on the low side, and the stated range ends below it.
By their numbers in this assay, from the lowest: compound 2; then compounds 1 and 3 (each within the scatter of the next).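

In this assay, furan-3-yl and thiophen-3-yl match in heavy atom count and ring size and differ only in the hetero atom, oxygen against sulfur, yet the exchange is not neutral at this aromatic carbon next to the ring nitrogen (a 6.3-fold higher number from compound 2 to compound 3 (0.80 log units; beyond the scatter)). The same position therefore responds to the identity of a single ring atom, which the earlier pair could not show, since 1H-pyrrol-2-yl and furan-3-yl differ in both the hetero atom and the point of attachment. The step between the other two compounds (a 2.0-fold higher number from compound 1 to compound 3 (0.30 log units; within the scatter)) lies within the scatter, which leaves compound 2 apart from both, and no available evidence explains why the oxygen ring stands out.

The compounds shown leave open how much the point of attachment matters, as furan-2-yl, thiophen-2-yl and 1H-pyrrol-3-yl do not appear among them. They also leave open whether a five-membered ring is needed at all, or whether a phenyl ring or an amine at this place would give a number close to that of compound 2.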